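Swapping 5-methylthiophen-2-yl for 3-methylphenyl on a shared core

The source may hold more compounds than are shown below. What is called first, only, known or untested is meant among the compounds shown, and "the series" means these compounds.

Compound 1 `COc1ccc(-c2nc(CNc3ccc(C(=O)NO)cc3)n(-c3ccccc3)n2)cc1`: > 20000 nM, a limit of the assay
Compound 2 `O=C(NO)c1ccc(NCc2nc(-c3cc4ccccc4s3)nn2-c2ccccc2)cc1`: 6110 nM
Compound 3 `Cc1ccc(-c2nc(CNc3ccc(C(=O)NO)cc3)n(-c3ccccc3)n2)s1`: 8450 nM

In a functional assay on MGC-803 cells (Homo sapiens) for antiproliferative activity, read by MTT assay, with a stated time of 72 h (a higher number here means a weaker inhibitor, a lower number a stronger inhibitor), compound 3 gives 8450 nM and lies within the scatter of compound 2 at 6110 nM. Compound 1 gives > 20000 nM, which is a limit and not a number.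

Compound 4 `Cc1cccc(-c2nc(CNc3ccc(C(=O)NO)cc3)n(-c3ccccc3)n2)c1` keeps the shared core and differs from compound 3 at one place: 3-methylphenyl in place of 5-methylthiophen-2-yl on an aromatic carbon. There, 3-methylphenyl stands in place of 5-methylthiophen-2-yl on an aromatic carbon, between two ring nitrogen atoms.

The measured changes at this same carbon are the guide. Placing 5-methylthiophen-2-yl in place of 4-methoxyphenyl gave an at least 2.3-fold lower number from compound 1 to compound 3 (0.37 log units; beyond the scatter), and 1-benzothiophen-2-yl in that place gave an at least 3.2-fold lower number from compound 1 to compound 2 (0.51 log units; beyond the scatter). Exchanging these two groups gave only a 1.4-fold higher number from compound 2 to compound 3 (0.14 log units; within the scatter).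

Among the compounds with values here, compound 1 is the only measured compound with a substituted phenyl group at this carbon, and its value is the limit of > 20000 nM. A small move toward a higher number is therefore expected, probably not clearly beyond the scatter. The estimated change is a 1.5-fold higher number from compound 3 to compound 4 (0.19 log units; within the scatter). For compound 4 the expected value is 13000 nM, with an estimated range from 5500 nM to 30000 nM.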

Compound 4, half-maximal inhibitory concentration: 8710 nM
Estimate against measurement, compound 4: 1.5-fold (0.17 log units) above; the range from low to high includes it.
By their numbers in this assay, from the lowest: compounds 2, 3 and 4 (each within the scatter of the next). At a limit, above all of these: compound 1.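

In this assay, a six-membered aromatic ring of carbon only serves at this carbon as well as the sulfur-containing rings: 3-methylphenyl in place of 5-methylthiophen-2-yl gives a 1.0-fold higher number from compound 3 to compound 4 (0.01 log units; within the scatter), and 3-methylphenyl in place of 1-benzothiophen-2-yl gives a 1.4-fold higher number from compound 2 to compound 4 (0.15 log units; within the scatter). Within the data shown here, until now the only phenyl group with a substituent at this carbon belonged to compound 1, so a phenyl ring as such could have gone with the poor result, but 3-methylphenyl in place of 4-methoxyphenyl gives an at least 2.2-fold lower number from compound 1 to compound 4 (0.36 log units; beyond the scatter), which separates the two. That step is only a bound, as compound 1 stands at a limit and not at a number: the limit of > 20000 nM in this assay, at which 1 of the 4 values shown sits.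

As far as these compounds go, whether the gap to compound 1 belongs to the methoxy group or to its place on the phenyl ring remains open, and a 4-methylphenyl or 3-methoxyphenyl group at this carbon would tell these apart. Also open, from the compounds shown here alone, is whether a more different group here, such as a phenyl ring carrying an amine or a carboxylic acid, would move the number beyond the scatter of compounds 2, 3 and 4.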